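A few compounds are considered here, and "the series" means these few. Any claim that something is new, unique, unknown or untested is made for them only; others in the source may bear on it.

Working notes on the cytotoxicity series.

Compound 1 `COC(=O)c1cc(-c2cccc(NC(=O)c3ccc(/C=C/C(=O)c4ccccc4OC)cc3)c2)on1` is the reference point. In an ADME assay on Vero cells (Chlorocebus sabaeus) for cytotoxicity, read by MTT assay, with a stated time of 72 h (a higher number here means that more compound is tolerated, a lower number that less compound is tolerated), compound 1 reaches only a limit, > 40 ug/mL. Compound 2 `COC(=O)c1cc(-c2cccc(NC(=O)c3ccc(/C=C/C(=O)c4ccc(C)cc4)cc3)c2)on1` likewise stops at a limit in this assay, > 80 ug/mL. Compound 3 `COC(=O)c1cc(-c2cccc(NC(=O)c3ccc(/C=C/C(=O)c4ccc(F)cc4F)cc3)c2)on1` also gives a limit in this assay, > 40 ug/mL. The changes among these three leave no readable size: a step that the two limits leave unreadable from compound 1 to compound 2, a step that the two limits leave unreadable from compound 1 to compound 3 and a step that the two limits leave unreadable from compound 2 to compound 3 all sit between limits. What can be said is summed up by the limit of > 40 ug/mL in this assay, at which 2 of the 3 values shown sit, and the limit of > 80 ug/mL in this assay, at which 1 of the 3 values shown sits: none of the three aryl ketone variants shows measurable toxicity within the tested range.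

Compound 4 `COC(=O)c1cc(-c2cccc(NC(=O)c3ccc(/C=C/C(=O)c4ccc(OC)cc4OC)cc3)c2)on1` is the next member. Relative to compound 1 the change is methoxy in place of hydrogen on an aromatic carbon. No measured step reports a readable size for such a change, so the only guide is that every compound shown stayed at a limit. For compound 4 a step that the limit leaves unreadable from compound 1 to compound 4 is therefore expected, meaning in practice no departure from the limit behaviour. The estimate for compound 4 in this assay is 60 ug/mL, with a range from 30 ug/mL to 120 ug/mL.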

Compound 4, half-maximal cytotoxic concentration: > 50 ug/mL
Compound 4: no number, only a limit (the forecaster's own chance of this, stated with the estimate: 75%); the middle value does not contradict the limit.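

In this assay, among these compounds, compound 4 gives > 50 ug/mL, which is a limit, so no step from compound 1, compound 2 or compound 3 to compound 4 can be read. The compounds shown leave open at what concentration any of these four aryl ketone variants becomes toxic to the cells.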